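A Chalcone Pair Swapping Diethylamino for Trifluoromethyl

The source may hold more compounds than are shown below. What is called first, only, known or untested is meant among the compounds shown, and "the series" means these compounds.

Of the compounds shown here, three of a shared core have been tested in a functional assay on SK-OV-3 cells (Homo sapiens) for antiproliferative activity, read by MTT assay, with a stated time of 24 h; a higher number here means a weaker inhibitor, a lower number a stronger inhibitor. Compound 1 `COc1ccc(C(=O)/C=C/c2ccc(F)cc2)c2c1C=CC(C)(C)O2` reaches only a limit of the assay, giving > 10000 nM in this assay. Compound 2 `COc1ccc(C(=O)/C=C/c2cccc(F)c2)c2c1C=CC(C)(C)O2` also sits at a limit, giving > 10000 nM. Among the compounds with values here, compound 3 `CCN(CC)c1ccc(/C=C/C(=O)c2ccc(OC)c3c2OC(C)(C)C=C3)cc1` gives 610 nM, the only full number among the three, so it stands alone on the scale while the other two are capped. The step that the two limits leave unreadable from compound 1 to compound 2 cannot be sized because both of its ends sit at the limit of > 10000 nM in this assay, at which 2 of the 3 values shown sit. The step of an at least 16-fold lower number from compound 1 to compound 3 (1.21 log units; beyond the scatter) is large and lowers the number strongly.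

Compound 4 `COc1ccc(C(=O)/C=C/c2ccc(C(F)(F)F)cc2)c2c1C=CC(C)(C)O2` has not yet been measured. It differs from compound 3 by trifluoromethyl in place of diethylamino on an aromatic carbon. Within the data shown here, the measured step that bears on this is the one from compound 1 to compound 3, where the diethylamino replaced fluoro and the number fell by a large margin. Compound 4 removes that same diethylamino and puts trifluoromethyl in its place, so a large upward step in this assay is expected, most likely back to a limit. The expected step is a 20-fold higher number from compound 3 to compound 4 (1.29 log units; beyond the scatter). Compound 4 is estimated to give about 12000 nM, with a range from 3000 nM to 40000 nM.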

Compound 4, half-maximal inhibitory concentration: > 10000 nM
Compound 4: a limit, no number; the forecaster's own chance of this, stated with the estimate: 70%; the middle value is on the limit's open side.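

Within the data shown here, at this aromatic carbon, para to a large group, the earlier compounds showed only that diethylamino gave a lower number than fluoro. With trifluoromethyl in place of diethylamino, this assay now gives an at least 16-fold higher number from compound 3 to compound 4 (1.21 log units; beyond the scatter), so a second group at this carbon fails to keep the full number that diethylamino gives, and the true size of the step may be larger than printed. Fluoro in compound 1 and trifluoromethyl in compound 4 cannot be ranked against each other, and this holds for every step with a limit at both ends, since none of these steps can be read: the limit of > 10000 nM in this assay, at which 3 of the 4 values shown sit.

Among the compounds shown, diethylamino is thus the only group at this carbon with a full number, but one group cannot tell whether the nitrogen or the ethyl groups on it carry the effect. A dimethylamino group, a plain amine or a methoxy group at the same carbon would begin to separate these possibilities, and a compound with diethylamino at the place that the fluoro of compound 2 occupies would test whether the position matters as well.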